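The source may hold more compounds than are shown below. What is called first, only, known or untested is meant among the compounds shown, and "the series" means these compounds.

In a functional assay on SW-620 cells (Homo sapiens) for cytotoxicity, read by MTT assay, with a stated time of 72 h (a lower number here means a stronger inhibitor, a higher number a weaker inhibitor), compound 1 `COc1cccc(/C=C2\CCC/C(=C\c3ccccc3Cl)C2=O)c1OC` gives 10300 nM and compound 3 `COc1cccc(/C=C2\CCC/C(=C\c3cccc(Cl)c3Cl)C2=O)c1OC` gives 16300 nM. Among the compounds with values here, these are the only two exact numbers so far, and they cannot be told apart: the data show a 1.6-fold higher number from compound 1 to compound 3 (0.20 log units; within the scatter), a step that puts chloro in place of hydrogen on an aromatic carbon. Compound 2 `COc1ccccc1/C=C1\CCC/C(=C\c2cccc(OC)c2OC)C1=O` has only a limit, > 20000 nM. Its step to compound 3 is also uninformative, with a floor inside the scatter: an at least 1.2-fold lower number from compound 2 to compound 3 (0.08 log units; that floor lies within the scatter).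

Compound 4 `COc1cccc(/C=C2\CCC/C(=C\c3ccc(Cl)c(Cl)c3)C2=O)c1OC` has 3,4-dichlorophenyl in place of the 2,3-dichlorophenyl of compound 3, with the same atoms joined differently: 3,4-dichlorophenyl in place of 2,3-dichlorophenyl on a double-bonded chain carbon bound to a double-bonded ring carbon. Within the data shown here, no measured step moves a chlorine directly, so the closest guide is the chloro addition in compound 3, a 1.6-fold higher number from compound 1 to compound 3 (0.20 log units; within the scatter). That step stayed within the scatter, so no clear change is expected in this assay. The estimate is a 1.3-fold lower number from compound 3 to compound 4 (0.10 log units; within the scatter). Compound 4 is expected to give about 13000 nM. The estimated range runs from 5500 nM to 20000 nM.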

Compound 4, half-maximal inhibitory concentration: 10000 nM
Compound 4: middle estimate off by 1.3-fold (0.11 log units), on the high side, within the range that was stated.
By their numbers in this assay, from the lowest: compounds 4, 1 and 3 (each within the scatter of the next). At a limit, above all of these: compound 2.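

In this assay, putting 3,4-dichlorophenyl in place of 2,3-dichlorophenyl on a double-bonded chain carbon bound to a double-bonded ring carbon gives a 1.6-fold lower number from compound 3 to compound 4 (0.21 log units; within the scatter), so this change has no clear effect. Putting 3,4-dichlorophenyl in place of 2-chlorophenyl likewise gives a 1.0-fold lower number from compound 1 to compound 4 (0.01 log units; within the scatter), so neither the added chlorine nor the arrangement of the two chlorines separates these three compounds here. Putting 3,4-dichlorophenyl in place of 2-methoxyphenyl gives an at least 2.0-fold lower number from compound 2 to compound 4 (0.30 log units; that floor lies within the scatter), a step that cannot be read, because compound 2 is known only as a limit: the limit of > 20000 nM in this assay, at which 1 of the 4 values shown sits.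

The aromatic rings shown carry only chlorine or methoxy, so it remains open whether an amine or a carboxylic acid at this place would shift the number beyond the scatter. Whether these similar numbers would also hold in other cell lines is open too.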